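Trifluoromethoxy for Trifluoromethyl on the Thiourea Analogue

The source may report more compounds than this note shows. Statements on the series, on what has been measured and on what is new or still open speak of the compounds shown alone.

Of the compounds shown here, three built on one shared core have been measured, and a fourth awaits its number. Compound 1 `CN1c2ccc(NC(=O)Nc3ccc(C(F)(F)F)cc3)cc2C(C)(C)C(=O)C1(C)C` was tested in a functional assay on A2780 cells (Homo sapiens) for inhibition, with a stated time of 72 h (a lower number here means a stronger inhibitor, a higher number a weaker inhibitor), and gives 2580 nM. Compound 3 `CN1c2ccc(NC(=O)Nc3ccc(OC(F)(F)F)cc3)cc2C(C)(C)C(=O)C1(C)C` differs from compound 1 by a single change, (trifluoromethoxy in place of trifluoromethyl on an aromatic carbon), and in this assay compound 3 gives 2400 nM. The step that this change made is a 1.1-fold lower number from compound 1 to compound 3 (0.03 log units; within the scatter), so the two values sit together.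

Compound 2 `CN1c2ccc(NC(=S)Nc3ccc(C(F)(F)F)cc3)cc2C(C)(C)C(=O)C1(C)C` carries a different core from compound 1; the difference between the two cores is not broken down here. In this assay compound 2 gives 3900 nM. Its value against that of compound 1 and against that of compound 3 lies within the scatter, so nothing separates the three in this assay.

Compound 4 `CN1c2ccc(NC(=S)Nc3ccc(OC(F)(F)F)cc3)cc2C(C)(C)C(=O)C1(C)C` has not yet been measured in this assay. It stands to compound 2 as compound 3 stands to compound 1: the change is trifluoromethoxy in place of trifluoromethyl on an aromatic carbon, and the two places agree word for word, so it is the same change seen once already. The step expected from compound 2 to compound 4 is a 1.1-fold lower number from compound 2 to compound 4 (0.05 log units; within the scatter), set beside the earlier 1.1-fold lower number from compound 1 to compound 3 (0.03 log units; within the scatter), and it rests on that one measured step alone. Compound 4 is accordingly expected to give about 3500 nM in this assay, with an estimated range from 1800 nM to 7000 nM.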

Compound 4, half-maximal inhibitory concentration: 5400 nM
Compound 4: the middle estimate sits 1.5-fold (0.19 log units) below what was measured; the range from low to high includes it.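

In this assay the same change on the core of compound 2 gives a 1.4-fold higher number from compound 2 to compound 4 (0.14 log units; within the scatter), and set beside the step on the core of compound 1 it offers no sign that the change behaves differently on the two cores: the same change on two cores in this assay, a 1.1-fold lower number (0.03 log units; within the scatter) from compound 1 to compound 3 and a 1.4-fold higher number (0.14 log units; within the scatter) from compound 2 to compound 4, 1.5-fold (0.17 log units) apart, within the scatter of two such steps. Trifluoromethoxy in place of trifluoromethyl on an aromatic carbon, para to a large group, thus leaves the number within the scatter on both cores, and the two steps agree as far as these measurements can tell. For the compounds shown here, this does not show that the change carries over in general, since the comparison rests on a single pair of compounds for each of only two cores, and steps this small could not reveal a modest real difference between those cores.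

The compounds shown hold only trifluoromethyl or trifluoromethoxy at this place, so it remains open whether a chlorine atom, a nitrile, an amine or a carboxylic acid there would move the number beyond the scatter. On these data alone, it is equally open whether any such group would give the same step on both cores.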